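Removal of the benzyl group on the pyrazole nitrogen

The source may hold more compounds than are shown below. What is called first, only, known or untested is meant among the compounds shown, and "the series" means these compounds.

Working notes on a small set of amidine-bearing analogues sharing one fused core. For the measured compounds named here, compound 1 `COc1cc(Nc2nc(C(=N)Nc3ccccc3)cc3c(-c4ccccc4)n[nH]c23)cc(OC)c1OC` is the only member with a number so far: in a functional assay on PC-3 cells (Homo sapiens) for cytotoxicity, read by MTT assay, with a stated time of 72 h (on this read-out higher numbers stand for weaker inhibition and lower numbers for stronger inhibition), compound 1 gives 5800 nM. Compound 2 `COc1ccc(Cn2nc(-c3ccccc3)c3cc(C(=N)Nc4cccc(C(F)(F)F)c4)nc(Nc4cc(OC)c(OC)c(OC)c4)c32)cc1` has no measurement in this assay, where compound 2 stands at "not determined" (no result reported), so no position on the scale can be stated for it. Compound 3 `COc1cc(Nc2nc(C(=N)Nc3cccc(C(F)(F)F)c3)cc3c(-c4ccccc4)n[nH]c23)cc(OC)c1OC` is the next analogue to be measured in this assay.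

The change from compound 2 to compound 3 is hydrogen in place of 4-methoxybenzyl on an aromatic nitrogen. Going by the values given here, no measured pair in the set isolates this change, so the size of the step cannot be read from the data; with compound 2 undetermined, no direction can be anchored either, and the expectation is at most a modest step, without a preferred direction beyond the scatter.

Compound 3 is expected to give about 4000 nM in this assay, estimated to fall between 1000 nM and 16000 nM, resting on compound 1 at 5800 nM as the only measured point of the series.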

Compound 3, half-maximal inhibitory concentration: 13900 nM
Compound 3: middle estimate off by 3.5-fold (0.54 log units), on the low side; the range from low to high includes it.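

Going by these compounds, compound 2 has no result in this assay, so the step from 4-methoxybenzyl to hydrogen on the aromatic nitrogen cannot be read, and the effect of that removal remains unknown. For the compounds shown here, with hydrogen on that nitrogen, the series now holds two measured points, and trifluoromethyl in place of hydrogen on an aromatic carbon gives a 2.4-fold higher number from compound 1 to compound 3 (0.38 log units; beyond the scatter), a move toward weaker inhibition and the first change whose size can be read. No measurement at hand accounts for this step.

Still open, on these data alone, is whether a methyl group, a longer alkyl chain or another benzyl group on the aromatic nitrogen would shift the number relative to hydrogen, and whether the trifluoromethyl step would keep its direction and size with 4-methoxybenzyl on that nitrogen. Also open, as far as these compounds go, is whether a carboxylic acid, an amine or a nitrile in place of trifluoromethyl on the same aromatic carbon would move the number the same way, since a single substituent gives no trend.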